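This account rests on a few compounds, and the source may have more. Where it says the series, first, only, none or still open, it means among the compounds named here.

Measured compounds in an assay on cells for positive allosteric modulation of Cystic fibrosis transmembrane conductance regulator variant F508del (Homo sapiens), with stated times of 10 min and 7 s, in the presence of a further agent that is not named here; on this read-out higher numbers stand for an effect only at larger amounts of compound and lower numbers for an effect already at smaller amounts:
compound 1 `CC1(C)Cc2c(sc(NC(=O)c3nnc[nH]3)c2C(N)=O)C(C)(C)O1` gives 467 nM
compound 2 `CC1(C)Cc2c(sc(NC(=O)C(C)(C)O)c2C(N)=O)C(C)(C)O1` gives 16 nM
compound 3 `CC(C)(C)CC(O)C(=O)Nc1sc2c(c1C(N)=O)CC(C)(C)OC2(C)C` gives 0.54 nM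

Among these three, compound 3 has the lowest number in this assay; its nearest neighbour is compound 2, with the step of a 30-fold lower number from compound 2 to compound 3 (1.47 log units; beyond the scatter), and its furthest is compound 1, with the step of an 860-fold lower number from compound 1 to compound 3 (2.94 log units; beyond the scatter). Compound 4 `CC1(C)Cc2c(sc(NC(=O)c3[nH]ncc3Cl)c2C(N)=O)C(C)(C)O1` shares the core of compound 3 but differs on the carbonyl carbon: a group of 6 heavy atoms (3 carbon, 2 nitrogen, 1 chlorine; one five-membered aromatic ring with 2 hetero atoms) in place of a group of 7 heavy atoms (6 carbon, 1 oxygen; no ring), on a carbonyl carbon.

Two of the measured steps bear on this change. The step of an 860-fold lower number from compound 1 to compound 3 (2.94 log units; beyond the scatter) shows what happens in this assay when a five-membered aromatic ring with three hetero atoms on the carbonyl carbon is exchanged for the open chain of compound 3; the step of a 29-fold lower number from compound 1 to compound 2 (1.47 log units; beyond the scatter) shows that the open-chain 1-hydroxy-1-methylethyl group also sits well below the triazolyl ring. Compound 4 carries a five-membered aromatic ring again, with two hetero atoms and a chlorine, so the reverse of the large downward step from compound 1 is the closest guide, tempered by the chance that this ring does not reach all the way back to compound 1. Compound 4 is therefore expected to show a large upward step in this assay, a 280-fold higher number from compound 3 to compound 4 (2.44 log units; beyond the scatter). The estimated value of compound 4 in this assay is 150 nM, with a range from 30 nM to 1000 nM.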

Compound 4, half-maximal effective concentration: 2 nM
Beside the measured number, compound 4's estimate is 75-fold (1.88 log units) above it, and the stated range ends above it.
By their numbers in this assay, from the lowest: compound 3; then compound 4; then compound 2; then compound 1.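

In this assay a five-membered aromatic ring on the carbonyl carbon turns out to be compatible with a low number: exchanging the ring of compound 1 for the ring with two hetero atoms and a chlorine gives a large change (a 230-fold lower number from compound 1 to compound 4 (2.37 log units; beyond the scatter)). Open chains therefore do not always sit below rings at this place, for compound 2 lies above the ring-bearing compound 4 (an 8.0-fold lower number from compound 2 to compound 4 (0.90 log units; beyond the scatter)), while the longer chain of compound 3 keeps only a modest lead over that ring (a 3.7-fold higher number from compound 3 to compound 4 (0.57 log units; beyond the scatter)). Nothing available here accounts for these differences.

The compounds shown leave open what the chlorine itself contributes, since they do not tell whether the same ring with a hydrogen, a methyl or a bromine in that place would stay near compound 4. They also leave open how a phenyl ring, a pyridine ring or an amine on the carbonyl carbon would compare with the groups seen so far.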